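Swapping a pyridine for a thiophene on the side chain

The compounds below may be only part of what the source reports. "The series", "measured", "known", "first", "only" and "open" are said of these compounds alone.

Measured so far:
compound 1 `Nc1nc(NCc2cccs2)nc2sc(-c3cccs3)nc12`: 38 nM
compound 2 `Nc1nc(NCc2cccnc2)nc2sc(-c3ccco3)nc12`: 18.2 nM
compound 3 `Cc1ccc(-c2nc3c(N)nc(NCc4cccs4)nc3s2)o1`: 15.3 nM

These values come from an assay on CHO cells for displacement of a labelled ligand from adenosine receptor A3 (Homo sapiens), read by scintillation counting, with a stated time of 120 min; on this read-out higher numbers stand for weaker inhibition and lower numbers for stronger inhibition. Compound 2 stands second highest of the three, within the scatter of compound 3 and beyond the scatter above compound 1. Compound 4 `Nc1nc(NCc2ccsc2)nc2sc(-c3ccco3)nc12` differs from compound 2 by thiophen-3-yl in place of pyridin-3-yl on a saturated chain carbon bound to a nitrogen on an aromatic ring. Going by the values given here, no measured step changes this part of the molecule; the only measured step, a 2.5-fold lower number from compound 1 to compound 3 (0.40 log units; beyond the scatter), concerns the ring on the other side of the shared core and so gives no direct guide. With no bearing evidence, the expectation is a step of a 1.2-fold higher number from compound 2 to compound 4 (0.08 log units; within the scatter), not beyond the scatter. Compound 4 is therefore estimated at 22 nM, ranging from 8 nM to 60 nM.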

Compound 4, inhibition constant: 3.14 nM
Beside the measured number, compound 4's estimate is 7.0-fold (0.85 log units) above it; the measured number lies below the stated range.
By their numbers in this assay, from the lowest: compound 4; then compounds 3 and 2 (each within the scatter of the next); then compound 1.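

Going by these compounds alone, the ring on this saturated chain carbon clearly matters: the change to thiophen-3-yl gives a 5.8-fold lower number from compound 2 to compound 4 (0.76 log units; beyond the scatter), the first measured step at this position. The two rings have the same count of hydrogen-bond acceptors, so that count does not separate them, though they differ in ring size and hetero atom. Nothing available explains the step.

Still open, going by these compounds, is whether a phenyl or cyclohexyl ring here would give a lower number than thiophen-3-yl. Also open, on these data alone, is whether this gain persists when the ring on the other side of the shared core changes.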